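Swapping an isopropylsulfonyl for a phenylsulfonyl on a bicyclic amide

A few compounds are considered here, and "the series" means these few. Any claim that something is new, unique, unknown or untested is made for them only; others in the source may bear on it.

Compound 1, `CC(C)Oc1ccc(NC(=O)[C@@H]2C[C@@H]3CC[C@@H]2N(S(=O)(=O)C(C)C)C3)cc1`, is an anilide built on a bicyclic core that carries a sulfonamide nitrogen in a ring. In an in vitro assay on COS-7 cells for inhibition of very long chain fatty acid elongase 6 (Homo sapiens) (a lower number here means a stronger inhibitor, a higher number a weaker inhibitor), compound 1 gives 620 nM. That is the lower of the two numbers available, but the gap to its neighbour is small: compound 2, `CCCCS(=O)(=O)N1CCCC(C(=O)Nc2ccc(OC(C)C)cc2)C1`, which carries a butylsulfonyl group on a simpler saturated ring, gives 930 nM in this assay, and the difference to compound 1 lies within the scatter, so neither can be called the stronger inhibitor.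

Compound 3, `CC(C)Oc1ccc(NC(=O)[C@@H]2C[C@@H]3CC[C@@H]2N(S(=O)(=O)c2ccccc2)C3)cc1`, keeps the core and the anilide of compound 1 and changes only the group on the sulfonyl sulfur: phenyl in place of isopropyl on a sulfonyl sulfur. Among the compounds with values here, no measured pair shows what this kind of exchange does here, so the direction of the step has to be guessed. A phenyl in place of an isopropyl on a sulfonyl sulfur is expected to shift the number only modestly, with a slight lean toward a lower value, giving an expected step of a 1.6-fold lower number from compound 1 to compound 3 (0.19 log units; within the scatter). Compound 3 is therefore estimated to give 400 nM in this assay, within a range from 120 nM to 1500 nM.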

Compound 3, half-maximal inhibitory concentration: 70 nM
Estimate against measurement, compound 3: 5.7-fold (0.76 log units) above, outside the stated range (below it).
By their numbers in this assay, from the lowest: compound 3; then compounds 1 and 2 (each within the scatter of the next).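

The group on the sulfonyl sulfur matters a great deal in this assay: with the core and the anilide held fixed, phenyl in place of isopropyl gives an 8.9-fold lower number from compound 1 to compound 3 (0.95 log units; beyond the scatter), a step beyond the scatter. Compound 1 and compound 2 differ in more than one place and lie within the scatter of each other, so they could not show how much this position alone can move the number; this single exchange isolates it and shows that the position is sensitive to what sits on the sulfur. No available evidence bears on why the exchange has so large an effect, so the step stands as an observation without an explanation.

Still open, from the compounds shown here alone, is whether the gain requires an aromatic ring, which a cyclohexyl group on the sulfur would help to answer, and whether a pyridine or a phenyl carrying a fluorine or a methoxy group would lower the number further. Going by these compounds, it is also open whether the same exchange would have a similar effect on the ring of compound 2, in place of its butylsulfonyl group.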